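Shortening one hexenyl chain of compound 2

A few compounds are considered here, and "the series" means these few. Any claim that something is new, unique, unknown or untested is made for them only; others in the source may bear on it.

For the measured compounds named here, in a functional assay on PC-3 cells (Homo sapiens) for inhibition, read by colorimetric assay and MTT assay, with a stated time of 72 h (on this read-out higher numbers stand for weaker inhibition and lower numbers for stronger inhibition), compound 2 `C=CCCCCOc1ccccc1-c1cnc(OCCCCC=C)n1C` gives 9000 nM, the lowest of the three numbers measured so far. Compound 3 `C=CCCCCOc1ncc(-c2ccccc2OC)n1C` gives 24000 nM, and compound 1 `Cn1c2cnc1OCCCCCCCCOc1ccc(F)cc1-2` gives 52000 nM. Compound 4 `C=CCCCCOc1ccccc1-c1cnc(OC)n1C` differs from compound 2 by one change: hydrogen in place of pent-4-en-1-yl on a saturated chain carbon bound to an oxygen on an aromatic ring. Put another way, hex-5-en-1-yl gives way to methyl. Going by the values given here, the one measured step that bears on this is the same exchange made on the other chain, a 2.7-fold higher number from compound 2 to compound 3 (0.43 log units; beyond the scatter). A single step is a thin guide, but it points to a similar rise in this assay. The expected change is a 2.4-fold higher number from compound 2 to compound 4 (0.39 log units; beyond the scatter). Compound 4 is estimated at 22000 nM, with an expected range from 8000 nM to 55000 nM.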

Compound 4, half-maximal inhibitory concentration: 86000 nM
For compound 4 the middle estimate is 3.9-fold (0.59 log units) below the measured one; the whole stated range lies below it.
By their numbers in this assay, from the lowest: compound 2; then compound 3; then compounds 1 and 4 (each within the scatter of the next).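

In this assay the hex-5-en-1-yl chain at this position matters more than the earlier step suggested: methyl in its place gives a 9.6-fold higher number from compound 2 to compound 4 (0.98 log units; beyond the scatter) against a 2.7-fold higher number from compound 2 to compound 3 (0.43 log units; beyond the scatter) for the same exchange on the other chain. The two hex-5-en-1-yl chains of compound 2 therefore do not count equally here, although each exchange raises the number. The compounds shown leave open whether a butyl group or a longer chain at this position would keep the number of compound 2. Nothing given here explains the difference between the two chains.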